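Hydroxy-to-methyl swap on the tertiary chain carbon, amide series

The source may hold more compounds than are shown below. What is called first, only, known or untested is meant among the compounds shown, and "the series" means these compounds.

Measured so far:
compound 1, `CC(/C=C/CC(C)CCCC(C)(C)O)=C\C(=O)OC(C)C`, 5.06 in a physicochemical assay for lipophilicity; a lower number here means a more polar compound, a higher number a more lipophilic compound
compound 2, `CC(/C=C/CC(C)CCCC(C)(C)C)=C\C(=O)OC(C)C`, 7.56 in this assay
compound 3, `CCNC(=O)/C=C(C)/C=C/CC(C)CCCC(C)(C)O`, 3.15 in this assay

Two changes are covered. From compound 1 to compound 2 the change is methyl in place of hydroxy on a saturated chain carbon bound to three saturated chain carbons, and this gives a number 2.50 log units higher from compound 1 to compound 2 (beyond the scatter). From compound 1 to compound 3 the change is ethylamino in place of isopropoxy on a carbonyl carbon, and this gives a number 1.91 log units lower from compound 1 to compound 3 (beyond the scatter). Compound 3 stands lowest of the three, beyond the scatter from both others.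

Compound 4, `CCNC(=O)/C=C(C)/C=C/CC(C)CCCC(C)(C)C`, is not yet measured. Among the compounds with values here, it differs from compound 3 by methyl in place of hydroxy on a saturated chain carbon bound to three saturated chain carbons, the same change as the one from compound 1 to compound 2, at the same place word for word. The two cores differ by ethylamino in place of isopropoxy on a carbonyl carbon, so the change is now read on the amide core rather than the ester core; it occurs twice in all among the compounds shown.

Within the data shown here, with only one measured instance, the expectation rests on that one step. The step from compound 3 to compound 4 is expected to be about a number 2.50 log units higher from compound 3 to compound 4 (beyond the scatter), taken directly from a number 2.50 log units higher from compound 1 to compound 2 (beyond the scatter). For compound 4 the expected value in this assay is 5.65. The expected range for compound 4 runs from 5 to 6.3, widened somewhat since the change has not been seen on the amide core before.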

Compound 4, partition coefficient: 5.65
Compound 4: the middle estimate sits on the measured number at the digits printed, within the range that was stated.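

In this assay methyl in place of hydroxy gives a number 2.50 log units higher from compound 3 to compound 4 (beyond the scatter) on the amide core and a number 2.50 log units higher from compound 1 to compound 2 (beyond the scatter) on the ester core, so the step is the same size at the printed digits and carries over intact between these two cores. Read along the other edge, ethylamino in place of isopropoxy gives a number 1.91 log units lower from compound 2 to compound 4 (beyond the scatter) with methyl on the chain and a number 1.91 log units lower from compound 1 to compound 3 (beyond the scatter) with hydroxy there, so within these four compounds the two changes simply add, and no compound shown goes against this. That is one agreement on one pair of cores at one place on the chain, which sets no rule for any other core or group, and nothing available here accounts for the agreement.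

As far as these compounds go, whether the same additivity holds with an amine or a carboxylic acid in place of hydroxy on the saturated chain carbon stays open. Also open, from the compounds shown here alone, is whether it survives a longer chain than ethylamino on the carbonyl carbon, such as butylamino, or a ring-bearing group such as benzylamino there.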